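Swapping the aryl group: an azetidine sulfonamide series

The source may report more compounds than this note shows. Statements on the series, on what has been measured and on what is new or still open speak of the compounds shown alone.

Of the compounds shown here, two of a shared core have been measured in an assay on RPMI-8866 cells for inhibition of integrin alpha-4/beta-1 (Homo sapiens); a lower number here means a stronger inhibitor, a higher number a weaker inhibitor. Compound 1, with the structure `O=C(O)C[C@@H](NC(=O)[C@@H]1CCN1S(=O)(=O)c1cc(Cl)cc(Cl)c1)c1ccc(Cl)c(F)c1`, gives 11 nM. Compound 2, with the structure `O=C(O)C[C@@H](NC(=O)[C@@H]1CCN1S(=O)(=O)c1cc(Cl)cc(Cl)c1)c1ccc(OCF)cc1`, gives 0.72 nM. Among the measured compounds shown here, the one step between them, a 15-fold lower number from compound 1 to compound 2 (1.18 log units; beyond the scatter), shows that exchanging the aryl group on this chain carbon can move the number a long way. For the measured compounds named here, on the numbers so far, compound 2 stands lowest, with compound 1 as its only neighbour.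

Compound 3, with the structure `COc1ccc([C@@H](CC(=O)O)NC(=O)[C@@H]2CCN2S(=O)(=O)c2cc(Cl)cc(Cl)c2)cn1`, carries the change (6-methoxypyridin-3-yl in place of 4-(fluoromethoxy)phenyl on a saturated chain carbon bound to an amide-type nitrogen and a saturated chain carbon). The measured step from compound 1 to compound 2 bears on it only loosely: it concerns the same position but a different pair of groups, so it indicates that the position is sensitive rather than which way this particular exchange will go. A moderate change in either direction is therefore possible, with a slight lean toward a weaker inhibitor, and the expected step is a 2.8-fold higher number from compound 2 to compound 3 (0.44 log units; beyond the scatter). Compound 3 is estimated at 2 nM, within a range of 0.6 nM to 8 nM in this assay.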

Compound 3, half-maximal inhibitory concentration: 3 nM
Compound 3: middle estimate off by 1.5-fold (0.18 log units), on the low side; measured number inside the range.
By their numbers in this assay, from the lowest: compound 2; then compound 3; then compound 1.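

In this assay, the 6-methoxypyridin-3-yl group gives the first view of an aromatic ring containing a hetero atom at this position, and the number stays on the strong side of the series: a 4.2-fold higher number from compound 2 to compound 3 (0.62 log units; beyond the scatter), but a 3.7-fold lower number from compound 1 to compound 3 (0.56 log units; beyond the scatter). Both steps are modest yet beyond the scatter, so the three aryl groups fall into a clear order, with the pyridine-bearing compound 3 weaker than compound 2 but stronger than compound 1, which shows that a carbon-only ring is not required for a low number here. No measurement shown here gives a reason for this order.

The change from compound 2 to compound 3 alters several things at once: a ring carbon gives way to a ring nitrogen, and fluoromethoxy gives way to methoxy, so the step cannot be divided between them. A 4-methoxyphenyl group at the same place would separate these two changes, while a 6-aminopyridin-3-yl group would test whether the ring nitrogen can keep its number with an amine in place of the methoxy group.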